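Amide to Ester: What to Expect for Compound 3

This account rests on a few compounds, and the source may have more. Where it says the series, first, only, none or still open, it means among the compounds named here.

Compound 1 `CCn1c(C(=O)N(C)c2ccccc2)ccc1C(CC)(CC)c1ccc(OCC(O)C(C)(C)C)c(C)c1`: in an assay on HL-60 cells for agonist activity at vitamin D3 receptor (Homo sapiens), read by microscopy, with a stated time of 96 h (on this read-out higher numbers stand for an effect only at larger amounts of compound and lower numbers for an effect already at smaller amounts), compound 1 gives 6400 nM.
Compound 2 `CCn1c(C(=O)Nc2ccc(OC(F)(F)F)cc2)ccc1C(CC)(CC)c1ccc(OCC(O)C(C)(C)C)c(C)c1`: in this assay compound 2 gives only a limit, > 50000 nM.

Compound 2 stands at the edge of what this assay reports, its value being a limit rather than a number (the limit of > 50000 nM in this assay, at which 1 of the 2 values shown sits). Among the measured compounds shown here, the single measured step, an at least 7.8-fold higher number from compound 1 to compound 2 (0.89 log units; beyond the scatter), replaced methyl(phenyl)amino with (4-(trifluoromethoxy)phenyl)amino on the carbonyl carbon and weakened the effect clearly.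

Compound 3 `CCn1c(C(=O)OCc2ccc(F)cc2)ccc1C(CC)(CC)c1ccc(OCC(O)C(C)(C)C)c(C)c1` has not yet been measured. It differs from compound 2 by (4-fluorobenzyl)oxy in place of (4-(trifluoromethoxy)phenyl)amino on a carbonyl carbon, turning the amide into an ester. The measured step bears on this only loosely: it shows that the group on this carbonyl carbon matters and that a smaller substituent, as in compound 1, stays within the measurable range. Because compound 2 sits at a limit, the true size of the step cannot be fixed. Compound 3 is expected at 20000 nM, within 4000 nM to 60000 nM. The expected step is thus an at least 2.5-fold lower number from compound 2 to compound 3 (0.39 log units; beyond the scatter), with a real chance that only a limit is reported again.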

Compound 3, half-maximal effective concentration: > 50000 nM
Compound 3: no number, only a limit; the forecaster's own chance of this, stated with the estimate: 40%; middle value at least 2.5-fold (0.39 log units) from the limit.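

With an ester in place of the amide on the carbonyl carbon, compound 3 also gives only a limit in this assay, > 50000 nM. Swapping methyl(phenyl)amino for (4-fluorobenzyl)oxy gives an at least 7.8-fold higher number from compound 1 to compound 3 (0.89 log units; beyond the scatter), so a second group, one with no hydrogen-bond donor, also fails to give a number, and among these three compounds only the methyl(phenyl)amino group of compound 1 does. The step from compound 2 to compound 3 cannot be read, because both sit at the same limit: the limit of > 50000 nM in this assay, at which 2 of the 3 values shown sit.

From the compounds shown here alone, it remains open whether the methyl on the amide nitrogen or the unsubstituted phenyl ring of compound 1 is what keeps a measurable value. A simple dimethylamino group or a carboxylic acid at this carbonyl carbon could show how much of the phenyl-bearing group is needed at all.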